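The compounds below may be only part of what the source reports. "The series", "measured", "known", "first", "only" and "open" are said of these compounds alone.

Going by the values given here, only two compounds have been tested so far in a functional assay on HeLa cells (Homo sapiens) for inhibition, read by MTT assay, with a stated time of 72 h; a higher number here means a weaker inhibitor, a lower number a stronger inhibitor. There, compound 1 `COc1cccc(/C=C/C(=O)Nc2cc(OC)c(OC)c(OC)c2)c1` gives 16500 nM, the higher of the two numbers and so the weaker inhibitor, and the gap to compound 2 `C=C(Br)C(=O)Nc1cccc(/C=C/C(=O)NCc2ccc(C)cc2)c1`, at 1700 nM, lies beyond the scatter. Compound 3 `C=C(Br)C(=O)Nc1cccc(/C=C/C(=O)Nc2cc(OC)c(OC)c(OC)c2)c1` has not yet been measured. It keeps the core of compound 1, but ((1-bromoethenyl)carbonyl)amino stands in place of methoxy on an aromatic carbon of a six-membered aromatic ring of carbon only, meta to a large group (((1-bromoethenyl)carbonyl)amino in place of methoxy on an aromatic carbon). Among the compounds with values here, no measured pair isolates this change, so the evidence is indirect. Within the data shown here, the only guide is compound 2, which carries the same ((1-bromoethenyl)carbonyl)amino group on a different remainder and gives 1700 nM. That points to a clear move towards stronger inhibition in this assay, although the differing remainder keeps the expectation loose. The expected change is an 11-fold lower number from compound 1 to compound 3 (1.04 log units; beyond the scatter), a step beyond the scatter towards a lower number. For compound 3 the estimated value is 1500 nM, with an expected range from 300 nM to 6000 nM.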

Compound 3, half-maximal inhibitory concentration: 880 nM
Beside the measured number, compound 3's estimate is 1.7-fold (0.23 log units) above it; the measured number falls inside the stated range.
By their numbers in this assay, from the lowest: compounds 3 and 2 (each within the scatter of the next); then compound 1.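

In this assay, ((1-bromoethenyl)carbonyl)amino in place of methoxy on an aromatic carbon, meta to a large group, brings a 19-fold lower number from compound 1 to compound 3 (1.27 log units; beyond the scatter) on the core of compound 1. This is a large step beyond the scatter. Until now the change had been seen only indirectly, through a compound with a different remainder, whereas this pair isolates it at this position with everything else in compound 1 kept the same. No measured evidence here bears on why the step occurs.

The compounds shown leave open which part of the entering group carries the step, since it replaces methoxy as a whole: a plain acetylamino group, a propenoylamino group without the bromine, or a simple amine at the same place would separate the amide from the bromoethenyl part. They also leave open whether a (1-chloroethenyl)carbonylamino group would behave like the bromine-bearing group, and whether the same exchange would bring a step of similar size at another carbon of that ring.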